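The source may report more compounds than this note shows. Statements on the series, on what has been measured and on what is new or still open speak of the compounds shown alone.

Three compounds of the series have numbers in a functional assay on NCI-H322M cells (Homo sapiens) for inhibition, read by sulforhodamine B assay, with a stated time of 48 h; on this read-out higher numbers stand for weaker inhibition of growth and lower numbers for stronger inhibition of growth. Compound 1 `N=C(N)c1ccc(-c2ccc(-c3cc(Cl)cc(Cl)c3)s2)s1` gives 1660 nM, compound 3 `N=C(N)c1ccc(-c2ccc(-c3cncc4ccccc34)s2)s1` gives 1660 nM, and compound 2 `COc1ccc(-c2ccc(-c3ccc(C(=N)N)o3)o2)cc1` gives 2260 nM. Compound 2 carries the highest number of the three, yet its gaps to compound 1 and to compound 3 both sit within the scatter of repeated runs, so the three are not separated in this assay. Compound 4 `N=C(N)c1ccc(-c2ccc(-c3ccccc3)o2)o1` is not yet measured. It differs from compound 2 by hydrogen in place of methoxy on an aromatic carbon. Going by the values given here, no measured pair in this set shows a comparable change, so nothing here tells the direction of the step in this assay; a step inside the scatter is expected. The expected step of a 1.1-fold lower number from compound 2 to compound 4 (0.05 log units; within the scatter) is therefore small. Compound 4 is expected to give 2000 nM in this assay, within 700 nM to 6000 nM.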

Compound 4, concentration for 50% growth inhibition: 2120 nM
Compound 4: the middle estimate sits 1.1-fold (0.03 log units) below what was measured; the range from low to high includes it.
By their numbers in this assay, from the lowest: compounds 1, 3, 4 and 2 (each within the scatter of the next).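

In this assay, going by these compounds alone, hydrogen in place of methoxy on an aromatic carbon, para to a large group, gives a 1.1-fold lower number from compound 2 to compound 4 (0.03 log units; within the scatter) as the first step that can be read at one position. Methoxy and hydrogen at this position are therefore not separated in this assay. Nothing available gives a reason for this result.

Going by these compounds, whether an amine, a carboxylic acid or a longer chain at this position would separate from compound 2 remains open. On these data alone, it also remains open whether the same change reads alike on the core of compound 1.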